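The source may report more compounds than this note shows. Statements on the series, on what has been measured and on what is new or still open speak of the compounds shown alone.

Compound 1 `COc1cc(N)c(Cl)cc1C(=O)NC1CCN(CC2CCN(CCCCN)CC2)CC1` gives 6.47 nM in an assay on striatum for inhibition of 5-hydroxytryptamine receptor 4 (Cavia porcellus), read by radioligand binding; on this read-out lower numbers stand for stronger inhibition and higher numbers for weaker inhibition; compound 2 `COc1cc(N)c(Cl)cc1C(=O)NC1CCN(CC2CCN(CC(C)CN)CC2)CC1` gives 14.3 nM; compound 3 `COc1cc(N)c(Cl)cc1C(=O)NCC(O)CN1CCC(CN2CCC(N)CC2)CC1` gives 40.6 nM.

Compound 2 thus stands second highest of the three numbers, with compound 1 lower and compound 3 higher. Compound 4 `COc1cc(N)c(Cl)cc1C(=O)NC1CCN(CC2CCN(C(=O)C(C)N)CC2)CC1` has not yet been measured; it carries (1-aminoethyl)carbonyl in place of 2-(aminomethyl)propyl on an amine nitrogen in a ring. Among the compounds with values here, the only measured step touching this part of the molecule is a 2.2-fold higher number from compound 1 to compound 2 (0.34 log units; beyond the scatter), a reshaping of the chain on the same ring nitrogen. Within the data shown here, no measured pair shows what happens when the chain is exchanged for a carbonyl-linked group there, so the expectation is uncertain. Because a smaller alteration already gave a 2.2-fold higher number from compound 1 to compound 2 (0.34 log units; beyond the scatter), this larger alteration is expected to weaken binding further, a 4.9-fold higher number from compound 2 to compound 4 (0.69 log units; beyond the scatter). Compound 4 is therefore estimated at 70 nM, within 15 nM to 350 nM.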

Compound 4, half-maximal inhibitory concentration: 5.06 nM
Compound 4: middle estimate off by 14-fold (1.14 log units), on the high side; measured number below the stated range.
By their numbers in this assay, from the lowest: compounds 4 and 1 (each within the scatter of the next); then compound 2; then compound 3.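

On an amine nitrogen in a ring, (1-aminoethyl)carbonyl in place of 2-(aminomethyl)propyl gives a 2.8-fold lower number from compound 2 to compound 4 (0.45 log units; beyond the scatter) and shows that a chain joined through a carbonyl can stand here. In place of 4-aminobutyl, the same group gives a 1.3-fold lower number from compound 1 to compound 4 (0.11 log units; within the scatter) so the carbonyl link and the straight chain cannot be told apart in this binding read-out. Nothing available explains either step. Still open, on these data alone, is how much the terminal amine contributes, which a plain acetyl group would test, and whether a longer chain, such as (3-aminopropyl)carbonyl, would hold up on this nitrogen.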